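A few compounds are considered here, and "the series" means these few. Any claim that something is new, unique, unknown or untested is made for them only; others in the source may bear on it.

Compound 3 `Oc1cc(C(F)(F)F)ccc1-c1nc(-c2ccccc2O)n(-c2ccc(I)cc2)n1` gives 105% in a functional assay on PC-12 cells (Rattus norvegicus) for cytotoxicity, read by MTT assay, with stated times of 2 h and 24 h, tested at 10 uM; a higher number here means a stronger effect of the compound at the concentration tested, a lower number a weaker effect. Among the three compounds measured so far, its nearest number belongs to compound 1 `CCc1ccc(-n2nc(-c3ccc(C(F)(F)F)cc3O)nc2-c2ccccc2O)cc1`, which gives 107%, and its furthest to compound 2 `Oc1cc(C(F)(F)F)ccc1-c1nc(-c2ccccc2O)n(-c2ccc(Cl)cc2)n1`, which gives 96.1%; the steps read a number 2 percentage points lower from compound 1 to compound 3 (within the scatter) and a number 8.9 percentage points higher from compound 2 to compound 3 (within the scatter). Compound 4 `N#Cc1ccc(-n2nc(-c3ccc(C(F)(F)F)cc3O)nc2-c2ccccc2O)cc1` differs from compound 3 in one place: cyano in place of iodo on an aromatic carbon. The measured steps that bear on this change are the three at the same aromatic carbon, a number 10.9 percentage points lower from compound 1 to compound 2 (beyond the scatter), a number 2 percentage points lower from compound 1 to compound 3 (within the scatter) and a number 8.9 percentage points higher from compound 2 to compound 3 (within the scatter). Among the compounds with values here, only the first of them passes beyond the scatter, and no measured compound carries cyano, so a step no larger than the scatter is expected in this assay, with no fixed direction. Compound 4 is therefore estimated at 102%, with a range from 88% to 116%, which corresponds to an expected step of a number 3 percentage points lower from compound 3 to compound 4 (within the scatter).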

Compound 4, a percentage reported as activity, at one concentration (the size of the read-out at that concentration, not a potency): 98.9%
Compound 4: the middle estimate sits 3.1 percentage points above what was measured; low and high end bracket the measured number.
By their numbers in this assay, from the lowest: compounds 2, 4, 3 and 1 (each within the scatter of the next, the first and the last beyond it).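

In this assay cyano on this aromatic carbon stays within the scatter of all three earlier groups, with a number 6.1 percentage points lower from compound 3 to compound 4 (within the scatter) and a number 2.8 percentage points higher from compound 2 to compound 4 (within the scatter) and a number 8.1 percentage points lower from compound 1 to compound 4 (within the scatter) as its steps. Within the data shown here, its triple bond and hydrogen-bond acceptor therefore bring no step beyond the scatter, and the only such step at this position remains the one between ethyl and chloro, with cyano within the scatter of both. Nothing here explains these numbers. On these data alone, whether an amine, a carboxylic acid or a longer chain on this carbon would move the number beyond the scatter stays open.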